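The source may hold more compounds than are shown below. What is called first, only, known or untested is meant among the compounds shown, and "the series" means these compounds.

Compound 1 `CC(C)Cc1ccc2c(NCCCNCc3ccco3)ccnc2c1` is one of three compounds for which a physicochemical assay for acid dissociation, has been read. In this assay compound 1 gives 9.47, level at the digits shown with compound 3 `COc1ccc(F)cc1CNCCCNc1ccnc2cc(CCC(C)C)ccc12`, which in this assay gives 9.47; together these are the highest of the three numbers, yet the gap to compound 2 `COc1cccc(CNCCCNc2ccnc3cc(Oc4ccc(Cl)cc4)ccc23)c1O`, which in this assay gives 9.28, lies within the scatter, so no order can be drawn among them. Compound 4 `Fc1ccc(Oc2ccc3c(NCCCNCc4ccco4)ccnc3c2)cc1` has not yet been measured. It differs from compound 1 in one place: 4-fluorophenoxy in place of isobutyl on an aromatic carbon. Among the compounds with values here, no step between measured compounds bears directly on this change, so the expectation rests on what the three numbers show. Because compound 2 gives 9.28, a number within the scatter of compound 1, the change is expected to move the read-out little, if at all. The expected step is a number 0.09 log units lower from compound 1 to compound 4 (within the scatter), none beyond the scatter. Compound 4 is therefore estimated to give 9.38, within a range from 9.15 to 9.6.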

Compound 4, acid dissociation constant: 9.28
Compound 4: middle estimate off by 0.10 log units, on the high side; the range from low to high includes it.
By their numbers in this assay, from the lowest: compounds 2, 4, 1 and 3 (each within the scatter of the next).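

Within the data shown here, this is the first direct reading of a change at this position: in this assay, 4-fluorophenoxy in place of isobutyl on an aromatic carbon gives a number 0.19 log units lower from compound 1 to compound 4 (within the scatter) and thus no separation between the two compounds. Among these compounds, the result therefore extends what the earlier compounds could only suggest, since the exchange introduces a six-membered aromatic ring of carbon only and a hydrogen-bond acceptor, where isobutyl has neither, yet the read-out stays within the scatter. No measurement shown here accounts for this result.

As far as these compounds go, whether a charged group at this position, such as an amine or a carboxylic acid, would shift the read-out beyond the scatter remains open. So does the effect of a longer chain in place of isobutyl.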